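Swapping hydroxy for (3-chlorophenyl)amino on a carbonyl carbon

The source may report more compounds than this note shows. Statements on the series, on what has been measured and on what is new or still open speak of the compounds shown alone.

compound 1 `O=C(O)CCCCC(CCSC(=O)c1ccccc1)SC(=O)c1ccccc1` - "not active" (no number reported)
compound 2 `O=C(CCCCC1CCSS1)Nc1cccc2ccccc12` - 9.55%

Both compounds were tested in a functional assay on Bel-7402 cells (Homo sapiens) for inhibition, read by MTT assay, with a stated time of 24 h, tested at 1 ug/mL (a lower number here means less inhibition of growth, a higher number more inhibition of growth at the concentration tested), at a single concentration. Compound 1 has no single number there and is reported only as "not active" (no number reported) with no figure attached. Among the measured compounds shown here, compound 2 gives 9.55% in this assay and is the only compound with a number so far.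

The next compound to be measured is compound 3 `O=C(CCCCC(CCSC(=O)c1ccccc1)SC(=O)c1ccccc1)Nc1cccc(Cl)c1`, which keeps the core of compound 1 and changes one end of it ((3-chlorophenyl)amino in place of hydroxy on a carbonyl carbon). In words, (3-chlorophenyl)amino stands in place of hydroxy on a carbonyl carbon, which turns carboxy into (3-chlorophenyl)carbamoyl.

For the measured compounds named here, no measured pair isolates this change, so the data do not show its effect directly. A small upward step in this assay is expected, which may not clear the usual scatter. Going by the values given here, the only numerical anchor is compound 2 at 9.55%, so the expectation stays close to that level. The estimate for compound 3 is an expected 12% (likely range 2% to 30%).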

Compound 3, percent growth inhibition at one concentration: "not active" (no number reported)
No number was reported for compound 3; the estimate stays without a comparison.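

In this assay compound 1 gives "not active" (no number reported) and compound 3 gives "not active" (no number reported), so no step can be read between them. These compounds leave open whether (3-chlorophenyl)amino in place of hydroxy on a carbonyl carbon changes growth inhibition at all. No supporting evidence bears on this result.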